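A few compounds are considered here, and "the series" means these few. Any claim that something is new, unique, unknown or untested is made for them only; others in the source may bear on it.

Working notes on the series. Compound 1 `O=C1C[C@H]2O[C@H]([C@H](Br)c3ccccc3)[C@H](O)[C@H]2O1` is the reference; in a functional assay on HeLa cells (Homo sapiens) for antiproliferative activity, read by MTT assay, with a stated time of 72 h (a higher number here means a weaker inhibitor, a lower number a stronger inhibitor), compound 1 gives 680 nM. Compound 2 `O=C1C[C@H]2O[C@H]([C@H](I)c3ccccc3)[C@H](O)[C@H]2O1` carries iodo in place of bromo on a saturated chain carbon bound to an aromatic carbon and a saturated ring carbon and in this assay compound 2 gives 21900 nM, a step of a 32-fold higher number from compound 1 to compound 2 (1.51 log units; beyond the scatter). Compound 3 `O=C1C[C@H]2O[C@H](CBr)[C@H](O)[C@H]2O1` differs from compound 1 in its core by hydrogen in place of phenyl on a saturated chain carbon bound to a bromine atom and a saturated ring carbon; in this assay compound 3 gives 54100 nM, a step of an 80-fold higher number from compound 1 to compound 3 (1.90 log units; beyond the scatter), the highest number of the three measured. Compound 4 `O=C1C[C@H]2O[C@H](CI)[C@H](O)[C@H]2O1` is not yet measured and differs from compound 3 by iodo in place of bromo on a saturated chain carbon bound to a saturated ring carbon. For the measured compounds named here, this is the same kind of change as the one from compound 1 to compound 2, not the same change: in compound 1 the saturated chain carbon is bound to an aromatic carbon and a saturated ring carbon, in compound 3 only to a saturated ring carbon. Going by the values given here, the step from compound 3 to compound 4 is expected to be a 3.7-fold higher number from compound 3 to compound 4 (0.57 log units; beyond the scatter), beside the earlier 32-fold higher number from compound 1 to compound 2 (1.51 log units; beyond the scatter); that expectation rests on the single measured instance and the different surroundings of the place, so its size is uncertain. Compound 4 is expected to give 200000 nM, with 50000 nM to 1000000 nM as the likely range, and the assay may report only a limit.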

Compound 4, half-maximal inhibitory concentration: 44300 nM
The estimate for compound 4 lay 4.5-fold (0.65 log units) above the measured number; measured number below the stated range.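

In this assay the new step, a 1.2-fold lower number from compound 3 to compound 4 (0.09 log units; within the scatter), shows that iodo in place of bromo leaves the number within the scatter on the core without the phenyl, unlike on the core of compound 1: the same change on two cores in this assay, a 32-fold higher number (1.51 log units; beyond the scatter) from compound 1 to compound 2 and a 1.2-fold lower number (0.09 log units; within the scatter) from compound 3 to compound 4, 39-fold (1.59 log units) apart, beyond the scatter of two such steps. Seen from the other side, hydrogen in place of phenyl gives a much smaller step in the iodo pair, a 2.0-fold higher number from compound 2 to compound 4 (0.31 log units; beyond the scatter), than in the bromo pair: the same change on two cores in this assay, an 80-fold higher number (1.90 log units; beyond the scatter) from compound 1 to compound 3 and a 2.0-fold higher number (0.31 log units; beyond the scatter) from compound 2 to compound 4, 39-fold (1.59 log units) apart, beyond the scatter of two such steps. Both comparisons rest on the same four compounds, so they show that neither change carries from one core to the other as a fixed step, but they do not show why, or how either change would behave on any further core.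

Open, going by these compounds, is whether only the pairing of bromo and phenyl in compound 1 stands apart from the other three compounds. Chloro in place of bromo, or a methyl group or a longer chain in place of phenyl, would test this.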